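A few compounds are considered here, and "the series" means these few. Any claim that something is new, unique, unknown or untested is made for them only; others in the source may bear on it.

In a functional assay on HEY cells (Homo sapiens) for cytotoxicity, read by MTT assay, with a stated time of 72 h (on this read-out lower numbers stand for stronger inhibition and higher numbers for weaker inhibition), compound 1 `COc1cccc(CNC(=O)c2nc(Br)c3cccnc3c2N[C@H]2CC[C@H](N)CC2)c1` gives 7000 nM. Going by the values given here, compound 2 `N[C@H]1CC[C@H](NC(=O)c2nc(Br)c3cccnc3c2NCc2ccc(F)cc2)CC1` gives 7100 nM, so the two values lie within the usual scatter of each other and do not separate compound 1 from the only other compound measured. Compound 3 `N[C@H]1CC[C@H](Nc2c(C(=O)NCc3ccc(Cl)cc3Cl)nc(Br)c3cccnc23)CC1` has not yet been measured in this assay. It keeps the core of compound 1 but carries 2,4-dichlorophenyl in place of 3-methoxyphenyl on a saturated chain carbon bound to an amide-type nitrogen. Among the compounds with values here, no measured pair of compounds differing in one place shows how large such a change might be, so the expectation remains loose. Only a small move towards stronger inhibition is expected, with an estimated 1.6-fold lower number from compound 1 to compound 3 (0.19 log units; within the scatter). For compound 3 the expected value is 4500 nM, with an estimated range from 1500 nM to 12000 nM.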

Compound 3, half-maximal inhibitory concentration: 5000 nM
Estimate against measurement, compound 3: 1.1-fold (0.05 log units) below; the range from low to high includes it.
By their numbers in this assay, from the lowest: compounds 3, 1 and 2 (each within the scatter of the next).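

In this assay, putting 2,4-dichlorophenyl in place of 3-methoxyphenyl on a saturated chain carbon bound to an amide-type nitrogen gives a 1.4-fold lower number from compound 1 to compound 3 (0.15 log units; within the scatter), the first step read at this position. The exchange removes the hydrogen-bond acceptor counted in 3-methoxyphenyl and brings in two chlorine atoms, yet the read-out does not separate the two compounds, so this one change shows no measurable effect at this position. Nothing measured on these compounds offers an explanation for this result. The compounds shown leave open whether this insensitivity extends to very different groups on the ring, such as an amine or a carboxylic acid. They also leave open whether a longer chain in place of the saturated chain carbon would move the value beyond the scatter.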